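This account rests on a few compounds, and the source may have more. Where it says the series, first, only, none or still open, it means among the compounds named here.

In a functional assay on CNE-2 cells (Homo sapiens) for antiproliferative activity, read by sulforhodamine B assay, with a stated time of 48 h (a lower number here means a stronger inhibitor, a higher number a weaker inhibitor), compound 1 (`COc1cc(OC)c(/C=C/C(=O)C(=Cc2ccc(O)c(OC)c2)C(=O)/C=C/c2c(OC)cc(OC)cc2OC)c(OC)c1`) gives 1350 nM and compound 2 (`COc1cc(OC)c(/C=C/C(=O)C(=Cc2ccc(O)c(F)c2)C(=O)/C=C/c2c(OC)cc(OC)cc2OC)c(OC)c1`) gives 1580 nM. For the measured compounds named here, these two values lie within the scatter of each other, so compound 2 holds no separate rank on the numbers so far. The next compound is compound 3 (`COc1cc(OC)c(/C=C/C(=O)C(=Cc2cc(Br)c(O)c(OC)c2)C(=O)/C=C/c2c(OC)cc(OC)cc2OC)c(OC)c1`), and the change from compound 2 is 3-bromo-4-hydroxy-5-methoxyphenyl in place of 3-fluoro-4-hydroxyphenyl on a double-bonded chain carbon bound to a double-bonded chain carbon. Going by the values given here, one measured step bears on this change: a 1.2-fold higher number from compound 1 to compound 2 (0.07 log units; within the scatter), with fluoro in place of methoxy on an aromatic carbon. That step stayed within the scatter, and compound 3 carries a methoxy group on the ring that changes, as compound 1 does. Among the compounds with values here, no measured step involves bromo, so that part of the change remains untested and the range is kept wide. No step beyond the scatter is expected in this assay, in either direction. The expected change is a 1.2-fold lower number from compound 2 to compound 3 (0.08 log units; within the scatter). For compound 3 the estimated value is 1300 nM, with an expected range of 500 nM to 3500 nM.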

Compound 3, half-maximal inhibitory concentration: 1320 nM
Compound 3: the middle estimate sits 1.0-fold (0.01 log units) below what was measured; the range from low to high includes it.
By their numbers in this assay, from the lowest: compounds 3, 1 and 2 (each within the scatter of the next).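

Bromo is the new feature here: in this assay, placing it on an aromatic carbon of the ring of compound 1 gives a step within the scatter (a 1.0-fold lower number from compound 1 to compound 3 (0.01 log units; within the scatter)), so this ring position accepts a bromo substituent with no measurable change in the number. The whole-ring exchange, 3-bromo-4-hydroxy-5-methoxyphenyl in place of 3-fluoro-4-hydroxyphenyl on a double-bonded chain carbon bound to a double-bonded chain carbon, also stays within the scatter (a 1.2-fold lower number from compound 2 to compound 3 (0.08 log units; within the scatter)), so with the earlier fluoro for methoxy step, all three ring patterns now remain unseparated in this assay and none holds a rank of its own. No measurement shown here offers an explanation for this flat result.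

From the compounds shown here alone, all three compounds keep the 4-hydroxy group and the rest of the shared core, so what happens when that hydroxy gives way to an amine or a methyl ether remains open. For the compounds shown here, it is also open whether a carboxylic acid or a longer chain at the bromo position would produce the first step beyond the scatter.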